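Swapping the aniline on a urea-bearing core

This account rests on a few compounds, and the source may have more. Where it says the series, first, only, none or still open, it means among the compounds named here.

Measured compounds:
- compound 1, `CCc1ccc(Nc2cc(NC(=O)Nc3cc(OC)cc(OC)c3)ncn2)cc1`: 66.2%
- compound 2, `Cc1cc(F)cc(Nc2cc(NC(=O)Nc3c(Cl)cccc3Cl)ncn2)c1`: 49.1%
- compound 3, `CC(C)(C)c1ccc(Nc2cc(NC(=O)Nc3c(Cl)cccc3Cl)ncn2)cc1`: 42.3%

All three were tested in a functional assay on HCC827 cells (Homo sapiens) for inhibition, read by MTT assay, with a stated time of 48 h, tested at 10 uM; on this read-out higher numbers stand for more inhibition at the one concentration tested (going by the name of the read-out) and lower numbers for less inhibition. Compound 1 gives 66.2%, the highest of the three numbers. Compound 2 gives 49.1%, and compound 3 gives 42.3%; both gaps to compound 1 lie beyond the usual scatter, so compound 1 stands clearly on top here. For the measured compounds named here, compound 2 and compound 3 differ from compound 1 in more than one place, so no single step between measured compounds can be read off.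

The new compound 4, `COc1cc(NC(=O)Nc2cc(Nc3cc(I)ccc3OC)ncn2)cc(OC)c1`, keeps the rest of compound 1 and changes one part: 5-iodo-2-methoxyphenyl in place of 4-ethylphenyl on a nitrogen on an aromatic ring. Going by the values given here, no measured pair shows this change, so its effect is unknown. Because compound 1 gives 66.2%, the starting point is high, and the expected step of a number 11.2 percentage points lower from compound 1 to compound 4 (beyond the scatter) is a modest drop, of a size near the scatter. Compound 4 is therefore estimated at 55%, expected between 25% and 80%.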

Compound 4, a percentage reported as inhibition, at one concentration (the size of the read-out at that concentration, not a potency): 71%
Estimate against measurement, compound 4: 16 percentage points below; the measured number falls inside the stated range.
By their numbers in this assay, from the lowest: compounds 3 and 2 (each within the scatter of the next); then compounds 1 and 4 (each within the scatter of the next).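

Putting 5-iodo-2-methoxyphenyl in place of 4-ethylphenyl on the nitrogen on an aromatic ring gives, in this assay, a number 4.8 percentage points higher from compound 1 to compound 4 (within the scatter) and so leaves the two compounds indistinguishable on this read-out. For the compounds shown here, this is the first single change that can be read in this set, and it shows that this position accepts a quite different substituted phenyl ring, one carrying iodine and methoxy instead of ethyl, with no loss beyond the scatter. No measurement here explains why the two groups read alike.

As far as these compounds go, the iodine and the methoxy entered together, so their separate contributions remain unknown. From the compounds shown here alone, it is also open how this position would respond to a ring carrying an amine or a carboxylic acid, or to a group other than a phenyl ring.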